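Swapping a halogenated phenyl ring on a phenethyl thioether

The source may hold more compounds than are shown below. What is called first, only, known or untested is meant among the compounds shown, and "the series" means these compounds.

Measured so far in an assay on isolated protein for inhibition of Amine oxidase [flavin-containing] B (Homo sapiens); a lower number here means a stronger inhibitor, a higher number a weaker inhibitor:
- Compound 1, `C#CCNC1CCc2c(SCCc3ccc(Br)cc3)cccc21`, gives 85300 nM
- Compound 2, `C#CCNC1CCc2c(SCc3cccc(F)c3)cccc21`, gives 1480 nM
- Compound 3, `C#CCNC1CCc2c(SCc3ccc(Cl)c(Cl)c3)cccc21`, gives 2840 nM

Compound 1 stands highest of the three, and its gaps to compound 3 and to compound 2 both lie well beyond the scatter. Among the measured compounds shown here, compounds 2 and 3 differ from compound 1 in more than one place, so no single-change step is available among the measured set.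

Compound 4, `C#CCNC1CCc2c(SCCc3cccc(Cl)c3)cccc21`, differs from compound 1 by 3-chlorophenyl in place of 4-bromophenyl on a saturated chain carbon, two bonds along the chain from a sulfur. For the measured compounds named here, no measured pair shows a change like this one, so the expectation rests on the spread seen so far. The step from compound 1 to compound 4 in this assay is expected to be a modest drop, a 2.8-fold lower number from compound 1 to compound 4 (0.45 log units; beyond the scatter). Compound 4 is therefore estimated at 30000 nM, with a range from 8000 nM to 110000 nM.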

Compound 4, half-maximal inhibitory concentration: 82400 nM
Estimate against measurement, compound 4: 2.7-fold (0.44 log units) below, within the range that was stated.
By their numbers in this assay, from the lowest: compounds 2 and 3 (each within the scatter of the next); then compounds 4 and 1 (each within the scatter of the next).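

In this assay the swap of 4-bromophenyl for 3-chlorophenyl on this chain gives a 1.0-fold lower number from compound 1 to compound 4 (0.02 log units; within the scatter) and so leaves the two compounds reading alike. Among the compounds shown here, this is the first single-change pair in the set, and it shows that at this position the two halogenated phenyl rings cannot be told apart. No supporting data bear on why this is so. The swap alters both the halogen and its ring position at once, so 4-chlorophenyl would be needed to separate the two. On these data alone, how an unsubstituted phenyl or a pyridine ring would read here also remains open.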